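From tert-Butyl to a Benzyl Ester Arm on Compound 2

This account rests on a few compounds, and the source may have more. Where it says the series, first, only, none or still open, it means among the compounds named here.

Compound 1: `COC(=O)/C=C/c1cccc(N(Cc2ccccc2)C(=O)C2CCCCC2)c1` — > 1000 nM in an assay on isolated protein with Bile acid receptor (Homo sapiens) as the target; on this read-out higher numbers stand for an effect only at larger amounts of compound and lower numbers for an effect already at smaller amounts
Compound 2: `COC(=O)/C=C/c1cccc(N(Cc2ccc(C(C)(C)C)cc2)C(=O)C2CCCCC2)c1` — > 1000 nM

Compound 1 is known only by a limit of the assay rather than a number. The same holds for compound 2, whose value is also a limit. Both values sit at the same limit (the limit of > 1000 nM in this assay, at which 2 of the 2 values shown sit), so compound 2 stands at the edge of what the assay can report. Among the measured compounds shown here, the step that the two limits leave unreadable from compound 1 to compound 2 therefore cannot be read, and it is the only measured step available.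

Compound 3, `COC(=O)/C=C/c1cccc(N(Cc2ccc(/C=C/C(=O)OCc3ccccc3)cc2)C(=O)C2CCCCC2)c1`, differs from compound 2 by 2-(benzyloxycarbonyl)ethenyl in place of tert-butyl on an aromatic carbon. For the measured compounds named here, no measured step shows how this assay responds to such a change, so the expectation rests on compound 2 alone. Because compound 2 gives > 1000 nM, compound 3 is expected to land near that limit, with an estimated step that the limit leaves unreadable from compound 2 to compound 3. The estimate for compound 3 is 2000 nM, ranging from 200 nM to 20000 nM.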

Compound 3, half-maximal effective concentration: > 1000 nM
Compound 3: no number, only a limit; the forecaster's own chance of this, stated with the estimate: 55%; the middle value lies beyond the limit too.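

In this assay compound 3 gives > 1000 nM, which is a limit and not a number. The steps among compound 1, compound 2 and compound 3 therefore cannot be read: the limit of > 1000 nM in this assay, at which 3 of the 3 values shown sit.

The compounds shown leave open whether tert-butyl or 2-(benzyloxycarbonyl)ethenyl changes the amount of compound needed for an effect.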